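Swapping one chlorobenzyl pattern for another on a tolerated scaffold

The source may hold more compounds than are shown below. What is called first, only, known or untested is meant among the compounds shown, and "the series" means these compounds.

Compound 1 `O=C1c2sccc2NS(=O)(=O)N1Cc1ccccc1` in an ADME assay on MT4 cells (Homo sapiens) for cytotoxicity, read by MTT assay, with a stated time of 4 days (a lower number here means that less compound is tolerated, a higher number that more compound is tolerated), gives 374000 nM. Compound 2 `O=C1c2sccc2N(Cc2cccc(Cl)c2)S(=O)(=O)N1Cc1ccccc1` in this assay reaches only the limit of the assay, > 298000 nM, so no exact number exists for it. The step that the limit leaves unreadable from compound 1 to compound 2 therefore stays unreadable, as the limit of > 298000 nM in this assay, at which 1 of the 2 values shown sits, shows. Compound 3 `O=C1c2sccc2N(Cc2ccc(Cl)cc2Cl)S(=O)(=O)N1Cc1ccccc1` differs from compound 2 by 2,4-dichlorophenyl in place of 3-chlorophenyl on a saturated chain carbon bound to a sulfonamide nitrogen in a ring. For the measured compounds named here, no measured step resembles this change, so no shift beyond the scatter can be expected in this assay. Compound 3 is expected to sit near 300000 nM, between 100000 nM and 600000 nM. That estimate amounts to the step that the limit leaves unreadable from compound 2 to compound 3, expected rather than measured.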

Compound 3, half-maximal cytotoxic concentration: 247000 nM
For compound 3 the middle estimate is 1.2-fold (0.08 log units) above the measured one; the range from low to high includes it.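

With an exact number, compound 3 shows that 2,4-dichlorobenzyl can replace hydrogen on the sulfonamide nitrogen in the ring with only a 1.5-fold lower number from compound 1 to compound 3 (0.18 log units; within the scatter) in this assay. Putting 2,4-dichlorophenyl in place of 3-chlorophenyl gives an at least 1.2-fold lower number from compound 2 to compound 3 (0.08 log units; that floor lies within the scatter), so the second chlorine brings no shift that can be told from the scatter. The step from compound 1 to compound 2 cannot be read, and compound 2 has only a limit: the limit of > 298000 nM in this assay, at which 1 of the 3 values shown sits.

The compounds shown leave open whether a carboxylic acid or an amine at this position, in place of the chlorobenzyl groups, would shift the number beyond the scatter.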